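Furan to thiophene on the ethenyl chain

The compounds below may be only part of what the source reports. "The series", "measured", "known", "first", "only" and "open" are said of these compounds alone.

Among the compounds with values here, in a functional assay on KB cells (Homo sapiens) for cytotoxicity (a higher number here means that more compound is needed for the effect, a lower number that less compound is needed), compound 2 (`COC1=C(C)C(=O)/C(=C(O)/C=C/c2ccco2)C(=O)C1(C)C`) gives 9.9 ug/mL and stands highest of the two numbers so far. Compound 1 (`COC1=C(C)C(=O)/C(=C(O)/C=C/c2ccc(C)cc2)C(=O)C1(C)C`) gives 3.9 ug/mL on the same scale. Compound 3 (`COC1=C(C)C(=O)/C(=C(O)/C=C/c2cccs2)C(=O)C1(C)C`) carries thiophen-2-yl in place of furan-2-yl on a double-bonded chain carbon bound to a double-bonded chain carbon. Within the data shown here, only one measured step bears on this change: a 2.5-fold higher number from compound 1 to compound 2 (0.40 log units; beyond the scatter) for furan-2-yl in place of 4-methylphenyl, modest but beyond the scatter. Among the measured compounds shown here, no thiophen-2-yl compound has been measured, so only a small shift toward lower numbers is expected in this assay, probably within the scatter. The estimated move is a 1.5-fold lower number from compound 2 to compound 3 (0.18 log units; within the scatter) at most modest in size. Compound 3 is estimated at 6.5 ug/mL (expected range 3 ug/mL to 14 ug/mL).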

Compound 3, concentration for half-maximal effect: 5.5 ug/mL
Estimate against measurement, compound 3: 1.2-fold (0.07 log units) above, within the range that was stated.
By their numbers in this assay, from the lowest: compounds 1, 3 and 2 (each within the scatter of the next, the first and the last beyond it).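

At this place, on a double-bonded chain carbon bound to a double-bonded chain carbon, thiophen-2-yl is not separated from furan-2-yl in this assay (a 1.8-fold lower number from compound 2 to compound 3 (0.26 log units; within the scatter)). Nor is it separated from 4-methylphenyl (a 1.4-fold higher number from compound 1 to compound 3 (0.15 log units; within the scatter)), so among these groups only the pair compound 1 and compound 2 lies beyond the scatter. Nothing at hand gives a cause for these readings.

Still open, on these data alone, is whether an amine or a carboxylic acid on the thiophen-2-yl ring moves the number beyond the scatter. Also open, as far as these compounds go, is what a longer chain in place of the ethenyl link, or any change on the shared core, would do.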